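The source may report more compounds than this note shows. Statements on the series, on what has been measured and on what is new or still open speak of the compounds shown alone.

Measured so far in an ADME assay (liver) for metabolic stability, with Liver microsome (Homo sapiens) as the target, using microsomes and NADPH, with a stated time of 30 min, tested at 1 uM (a lower number here means slower removal, a higher number faster removal of the compound), with two compounds:
- compound 1 `Nc1ccc(S(=O)(=O)N2CCN(c3ncc(C(O)(C(F)(F)F)C(F)(F)F)cc3-c3cccc(F)c3)CC2)cn1` gives 25 mL.min-1.g-1
- compound 2 `Nc1ccc(S(=O)(=O)N2CCN(c3ncc(C(O)(C(F)(F)F)C(F)(F)F)cc3-c3cnccc3F)CC2)cn1` gives 17 mL.min-1.g-1

On these numbers, compound 2 sits within the usual scatter of compound 1, so the two cannot be told apart. The next compound is compound 3 `Nc1ccc(S(=O)(=O)N2CCN(c3ncc(C(O)(C(F)(F)F)C(F)(F)F)cc3-c3cncc(F)c3)CC2)cn1`, which has the same atoms as compound 2, joined differently. It carries 5-fluoropyridin-3-yl in place of 4-fluoropyridin-3-yl on an aromatic carbon. This carbon belongs to a six-membered aromatic ring with 1 nitrogen and is ortho to a large group.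

For the measured compounds named here, no measured step tests this exact swap. The closest guide is a 1.5-fold lower number from compound 1 to compound 2 (0.17 log units; within the scatter), a change at the same place that replaced 3-fluorophenyl with 4-fluoropyridin-3-yl. That single step stayed within the scatter, and one step is thin evidence, so the range has to stay wide. No change beyond the scatter is expected here, and the expected step is a 1.2-fold higher number from compound 2 to compound 3 (0.07 log units; within the scatter). For compound 3 the estimated value is 20 mL.min-1.g-1, with an expected range of 10 mL.min-1.g-1 to 38 mL.min-1.g-1.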

Compound 3, intrinsic clearance in microsomes: 24 mL.min-1.g-1
For compound 3 the middle estimate is 1.2-fold (0.08 log units) below the measured one; low and high end bracket the measured number.
By their numbers in this assay, from the lowest: compounds 2, 3 and 1 (each within the scatter of the next).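

In this assay, the swap of 4-fluoropyridin-3-yl for 5-fluoropyridin-3-yl keeps the same atoms but joins them differently, and it gives a 1.4-fold higher number from compound 2 to compound 3 (0.15 log units; within the scatter) and so stays within the scatter. For the compounds shown here, this is the first test of how the atoms of this ring are arranged at this position, an aromatic carbon ortho to a large group, and the rearrangement cannot be told apart from no change at all. The second new comparison, 5-fluoropyridin-3-yl in place of 3-fluorophenyl, gives a 1.0-fold lower number from compound 1 to compound 3 (0.02 log units; within the scatter) and is also within the scatter, so the 3-fluorophenyl, 4-fluoropyridin-3-yl and 5-fluoropyridin-3-yl groups form a set of three that this read-out does not separate at this place on the shared core.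

On these data alone, all three groups are fluorinated six-membered aromatic rings, so it remains open whether something of a different kind here, such as an amine, a carboxylic acid or a longer chain, would shift the number beyond the scatter. Nothing shown here offers a measured reason for why these three compounds fall so close together.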